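Benzyl variation on the chromone triazole ether: cytotoxicity notes

A few compounds are considered here, and "the series" means these few. Any claim that something is new, unique, unknown or untested is made for them only; others in the source may bear on it.

The series keeps one core and varies the group on the saturated chain carbon bound to an aromatic nitrogen. Compound 1 `Cc1cccc(Cn2cc(COc3ccc4c(=O)ccoc4c3)nn2)c1` carries 3-methylphenyl there and in a functional assay on QGY7701 cells (Homo sapiens) for cytotoxicity, read by MTT assay, with a stated time of 48 h (on this read-out higher numbers stand for weaker inhibition and lower numbers for stronger inhibition), compound 1 gives 22400 nM. Compound 2 `O=c1ccoc2cc(OCc3cn(Cc4ccccc4Br)nn3)ccc12` carries 2-bromophenyl instead. In this assay compound 2 gives only a limit, > 100000 nM, and no number. The change reads as an at least 4.4-fold higher number from compound 1 to compound 2 (0.64 log units; beyond the scatter), and compound 2 therefore stands at the limit of > 100000 nM in this assay, at which 1 of the 2 values shown sits.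

Compound 3 `O=c1ccoc2cc(OCc3cn(Cc4ccccc4)nn3)ccc12` is the next step from compound 2: hydrogen in place of bromo on an aromatic carbon. Among the compounds with values here, the only measured step, the one from compound 1 to compound 2, swapped one substituted phenyl for another and does not reproduce this change, so it bears on it only loosely; it shows that the 2-bromophenyl compound 2 sits at the limit while the 3-methylphenyl compound 1 gives a measurable number. Since compound 2 is a limit, the size of an at least 2.0-fold lower number from compound 2 to compound 3 (0.30 log units; that floor lies within the scatter) cannot be fixed and is only expected to run toward lower numbers. For compound 3 the estimate in this assay is 50000 nM, with an expected range from 15000 nM to 150000 nM.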

Compound 3, half-maximal inhibitory concentration: > 100000 nM
Compound 3: a limit, no number; the forecaster's own chance of this, stated with the estimate: 40%; at least 2.0-fold (0.30 log units) between middle value and limit.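

Replacing bromo with hydrogen does not restore a measurable number in this assay: compound 3 gives only a limit, > 100000 nM. A measurable number therefore does not return simply with the loss of bromo, and among the compounds shown only the 3-methylphenyl group goes with one, with the step to phenyl reading as an at least 4.4-fold higher number from compound 1 to compound 3 (0.64 log units; beyond the scatter). The step from compound 2 to compound 3 cannot be read, so bromo and hydrogen cannot be ordered on this aromatic carbon, and the series now stands as follows: the limit of > 100000 nM in this assay, at which 2 of the 3 values shown sit.

As far as these compounds go, the true values of compound 2 and compound 3 remain unknown, as does whether the number for compound 1 follows the methyl group itself or its place on the ring. Also open, from the compounds shown here alone, is how an amine or a methoxy group on an aromatic carbon of the same ring would read in this assay.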